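From phenyl to pyridin-4-yl in a cytotoxicity series

This account rests on a few compounds, and the source may have more. Where it says the series, first, only, none or still open, it means among the compounds named here.

Compound 1 `COC(=O)N[C@H](C(=O)NN(CCC[C@@](O)(Cc1ccccc1)C(=O)N[C@H]1c2ccccc2C[C@H]1O)Cc1ccc(-c2noc(C)n2)cc1)C(C)(C)C`: > 10000 nM, a limit of the assay
Compound 2 `COC(=O)N[C@H](C(=O)NN(CCC[C@@](O)(Cc1ccccc1)C(=O)N[C@H]1c2ccccc2C[C@H]1O)Cc1ccc(-c2nccs2)cc1)C(C)(C)C`: > 10000 nM, a limit of the assay
Compound 3 `COC(=O)N[C@H](C(=O)NN(CCC[C@@](O)(Cc1ccccc1)C(=O)N[C@H]1c2ccccc2C[C@H]1O)Cc1ccc(-c2ccccc2)cc1)C(C)(C)C`: 7500 nM

All three compounds were tested in an ADME assay on MT4 cells (Homo sapiens) for cytotoxicity; on this read-out higher numbers stand for lower toxicity in this test and lower numbers for higher toxicity in this test. Among them, compound 3 alone has an actual number, 7500 nM. Compound 1 and compound 2 both rest at the limit of > 10000 nM in this assay, at which 2 of the 3 values shown sit.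

Compound 4 `COC(=O)N[C@H](C(=O)NN(CCC[C@@](O)(Cc1ccccc1)C(=O)N[C@H]1c2ccccc2C[C@H]1O)Cc1ccc(-c2ccncc2)cc1)C(C)(C)C` has pyridin-4-yl in place of the phenyl of compound 3, on an aromatic carbon and para to a large group: pyridin-4-yl in place of phenyl on an aromatic carbon.

Two measured steps exchange the group at this same place. One is an at least 1.3-fold lower number from compound 1 to compound 3 (0.12 log units; that floor lies within the scatter), and the other is an at least 1.3-fold lower number from compound 2 to compound 3 (0.12 log units; that floor lies within the scatter). The remaining pair gives a step that the two limits leave unreadable from compound 1 to compound 2. Neither floor shows a step beyond the scatter, so no step beyond the scatter is expected in this assay for compound 4. That expectation starts from compound 3 at 7500 nM. A report of only a limit would also be in keeping with that expectation.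

The estimated step is a 1.2-fold higher number from compound 3 to compound 4 (0.08 log units; within the scatter). For compound 4 the expected value is 9000 nM, with an estimated range of 4500 nM to 18000 nM.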

Compound 4, half-maximal cytotoxic concentration: > 10000 nM
Compound 4 gave a limit, no number; the forecaster's own chance of this, stated with the estimate: 50%; middle value at least 1.1-fold (0.04 log units) from the limit.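

In this assay, compound 4 gives > 10000 nM, a limit of the assay and not a number. Placing pyridin-4-yl in place of phenyl, on an aromatic carbon and para to a large group, gives an at least 1.3-fold higher number from compound 3 to compound 4 (0.12 log units; that floor lies within the scatter), so a six-membered aromatic ring with 1 hetero atom is now shown at this place and gives no lower number than the all-carbon ring of compound 3. The steps from compound 1 and from compound 2 to compound 4 cannot be read, and compound 3 remains the only one of the four with an actual number, while the other three share one limit: the limit of > 10000 nM in this assay, at which 3 of the 4 values shown sit.

From the compounds shown here alone, how far the true values of compound 1, compound 2 and compound 4 lie from that of compound 3 stays open, and so does whether any of these groups differs from phenyl by more than the scatter. Also open, going by these compounds, is whether a piperidine ring, an amine or a carboxylic acid at this same place would bring the read-out down to a measurable number or leave it at the limit.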